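Solubility notes: 4-methyl-2-oxopyrrolidin-1-yl on the shared core

The compounds below may be only part of what the source reports. "The series", "measured", "known", "first", "only" and "open" are said of these compounds alone.

In a physicochemical assay for solubility, read by LC-MS, in phosphate buffer, with a stated time of 24 h, at pH 7.4 (on this read-out higher numbers stand for higher solubility and lower numbers for lower solubility), compound 2 (`CN(c1ccn(C)n1)c1cnc(NCc2c(F)ccc3c2CCO3)n2cnnc12`) gives 130000 nM and sits level with compound 1 (`CN(c1ncco1)c1cnc(NCc2c(F)ccc3c2CCO3)n2cnnc12`) at 67000 nM on the two numbers available. Compound 3 (`C[C@H]1CC(=O)N(c2cnc(NCc3c(F)ccc4c3CCO4)n3cnnc23)C1`) carries 4-methyl-2-oxopyrrolidin-1-yl in place of methyl(1-methyl-1H-pyrazol-3-yl)amino on an aromatic carbon. The new group sits on the same aromatic carbon of the shared core, para to a large group. Among the measured compounds shown here, the only measured step, a 1.9-fold higher number from compound 1 to compound 2 (0.29 log units; within the scatter), exchanged one five-membered aromatic ring for another on a nitrogen and stayed within the scatter. Here the aromatic ring leaves altogether, and no measured compound shows such a change, so that step is only a weak guide. The data give no direction, and no step beyond the scatter is expected in this assay on this evidence. The expected change is a 1.3-fold lower number from compound 2 to compound 3 (0.11 log units; within the scatter) in this estimate, with wide uncertainty. Compound 3 is estimated at 100000 nM with a range of 30000 nM to 250000 nM as the expected bounds.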

Compound 3, solubility: 200000 nM
Compound 3: middle estimate off by 2.0-fold (0.30 log units), on the low side; measured number inside the range.
By their numbers in this assay, from the lowest: compounds 1, 2 and 3 (each within the scatter of the next, the first and the last beyond it).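

In this assay, 4-methyl-2-oxopyrrolidin-1-yl on this aromatic carbon replaces methyl(1-methyl-1H-pyrazol-3-yl)amino with a 1.5-fold higher number from compound 2 to compound 3 (0.19 log units; within the scatter), so here a five-membered non-aromatic ring takes the place of a group carrying a five-membered aromatic ring, and the two compounds stay level on this read-out. Among the compounds shown here, measured against methyl(1,3-oxazol-2-yl)amino, the same group gives a 3.0-fold higher number from compound 1 to compound 3 (0.47 log units; beyond the scatter), the first step in this short series to pass the scatter, though only a modest one, and it shows that a change at this position can move the number measurably. Nothing at hand accounts for either step.

As far as these compounds go, whether the plain 2-oxopyrrolidin-1-yl ring, without its methyl, or the opposite configuration at the defined stereocentre would read the same at this position remains open. Also open, from the compounds shown here alone, is how an open-chain amide, a morpholin-4-yl ring or a carboxylic acid on this aromatic carbon would compare with compound 3 on the shared core.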